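Swapping diethylamino for piperidin-1-yl on the chain

A few compounds are considered here, and "the series" means these few. Any claim that something is new, unique, unknown or untested is made for them only; others in the source may bear on it.

The three measured compounds share one core and a side chain attached through a saturated carbon to the amide-type nitrogen in the ring. In an ADME assay on 184B5 cells (Homo sapiens) for cytotoxicity, read by sulforhodamine B assay, with a stated time of 48 h (a higher number here means a weaker inhibitor of growth, a lower number a stronger inhibitor of growth), compound 3 `CCN(CC)CN1C(=O)/C(=N\c2nc3ccc(C)cc3s2)c2c(Cl)cccc21` gives 87800 nM, the highest of the three numbers, meaning the weakest effect on growth. Compound 1 `CCN(CC)CN1C(=O)/C(=N\c2nc3ccc(C)cc3s2)c2c(Br)cccc21` gives 34300 nM, and the change a 2.6-fold higher number from compound 1 to compound 3 (0.41 log units; beyond the scatter) is a modest step beyond the scatter. Compound 2 `Cc1ccc2nc(/N=C3\C(=O)N(CN4CCCCC4)c4ccccc43)sc2c1` gives 34900 nM; compound 1 and compound 2 differ in two places at once, and their two numbers lie within the scatter of each other.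

Compound 4 `Cc1ccc2nc(/N=C3\C(=O)N(CN4CCCCC4)c4cccc(Cl)c43)sc2c1` differs from compound 3 in one place: piperidin-1-yl in place of diethylamino on a saturated chain carbon bound to an amide-type nitrogen in a ring. Among the measured compounds shown here, no measured pair isolates this exchange, so its effect is not known from the data. For the measured compounds named here, the only hint is that compound 1 and compound 2, which carry the two side chains but also differ in the halogen, give numbers that do not separate. On that basis the expected step of a 1.5-fold lower number from compound 3 to compound 4 (0.17 log units; within the scatter) is small, with no direction established beyond the scatter. Compound 4 is therefore estimated at 60000 nM in this assay, in a range from 25000 nM to 150000 nM.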

Compound 4, concentration for 50% growth inhibition: 82300 nM
Compound 4: middle estimate off by 1.4-fold (0.14 log units), on the low side; the measured number falls inside the stated range.
By their numbers in this assay, from the lowest: compounds 1 and 2 (each within the scatter of the next); then compounds 4 and 3 (each within the scatter of the next).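

In this assay, the exchange of diethylamino for piperidin-1-yl on the chain now has a measured pair of its own: a 1.1-fold lower number from compound 3 to compound 4 (0.03 log units; within the scatter) shows that, with chloro on the aromatic carbon, the open chain and the six-membered ring do not separate. Chloro in place of hydrogen on an aromatic carbon, with piperidin-1-yl on the chain, gives a 2.4-fold higher number from compound 2 to compound 4 (0.37 log units; beyond the scatter), and together with a 2.6-fold higher number from compound 1 to compound 3 (0.41 log units; beyond the scatter) this means that both steps on the aromatic carbon pass the scatter, while the one step on the chain stays inside it. The data offer no measurement that explains either kind of step.

Among the compounds shown here, it remains open whether the two side chains would also stay together with hydrogen or bromo on the aromatic carbon, since the only pair that isolates them carries chloro. On these data alone, it is also open whether a side chain with a ring oxygen, such as morpholin-4-yl, or a different aromatic substituent, such as fluoro or methoxy, would move the number in either direction.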